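From pyrrolidin-1-yl to piperazin-1-yl on the chain

A few compounds are considered here, and "the series" means these few. Any claim that something is new, unique, unknown or untested is made for them only; others in the source may bear on it.

Compound 1 `COc1c(OCCCNCc2ccccc2)cc(O)c2c(=O)cc(-c3ccccc3)oc12`: 1570 nM
Compound 2 `COc1c(OCCCN2CCCC2)cc(O)c2c(=O)cc(-c3ccccc3)oc12`: 1390 nM

Both numbers come from a functional assay on A549 cells (Homo sapiens) for cytotoxicity, read by MTT assay, with a stated time of 48 h; a lower number here means a stronger inhibitor, a higher number a weaker inhibitor. Repeat measurements of a single compound naturally vary, and this scatter sets how large a difference must be before it means anything. Compound 2 stands level with compound 1 on these two numbers, so neither can be called the stronger.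

Compound 3 `COc1c(OCCCN2CCNCC2)cc(O)c2c(=O)cc(-c3ccccc3)oc12` keeps the shared core and alters one group: piperazin-1-yl in place of pyrrolidin-1-yl on a saturated chain carbon, three bonds along the chain from an oxygen on an aromatic ring. Within the data shown here, the only measured step at this place on the chain is a 1.1-fold lower number from compound 1 to compound 2 (0.05 log units; within the scatter). That swap replaced benzylamino with pyrrolidin-1-yl, and the two numbers stayed within the scatter. Among the measured compounds shown here, no measured compound yet carries piperazin-1-yl, and a single step is thin evidence, so the range must stay wide. On this basis, no step beyond the scatter is expected in this assay, in either direction. The estimated change is a 1.1-fold higher number from compound 2 to compound 3 (0.03 log units; within the scatter). For compound 3, the expected value is 1500 nM, with an estimated range of 650 nM to 3500 nM.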

Compound 3, half-maximal inhibitory concentration: 10100 nM
For compound 3 the middle estimate is 6.7-fold (0.83 log units) below the measured one; measured number outside the range, above it.
By their numbers in this assay, from the lowest: compounds 2 and 1 (each within the scatter of the next); then compound 3.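

In this assay the group at the end of this chain can matter after all: benzylamino and pyrrolidin-1-yl gave numbers within the scatter of each other, but piperazin-1-yl gives a 7.3-fold higher number from compound 2 to compound 3 (0.86 log units; beyond the scatter) and, measured against benzylamino, a 6.4-fold higher number from compound 1 to compound 3 (0.81 log units; beyond the scatter) as well. Compound 3 is therefore the weakest inhibitor of the three, so this position does not accept every amine ring equally, and the change that separates it from compound 2 is a larger, six-membered ring carrying a second nitrogen and one hydrogen-bond donor. Nothing measured here explains why this swap raises the number.

The compounds shown leave open whether the larger ring or the second nitrogen goes with the higher number, and a piperidin-1-yl group, a six-membered ring with only one nitrogen, would help to separate the two. A 4-methylpiperazin-1-yl group, which keeps both ring nitrogens but puts a methyl on the second, would likewise test whether the hydrogen on that nitrogen plays any part.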